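Aryl-Ethyl in Place of Alkynyl Ester on a Dihydropyridine

A few compounds are considered here, and "the series" means these few. Any claim that something is new, unique, unknown or untested is made for them only; others in the source may bear on it.

Measured compounds:
compound 1, `COCC1=C(C(=O)OC)C(c2cccc([N+](=O)[O-])c2)C(C(=O)OC)=C(C)N1`, 115 nM
compound 2, `C#CCCOC(=O)C1=C(C)NC(C)=C(C(=O)OC)C1c1cccc([N+](=O)[O-])c1`, 31 nM

Both were tested in a functional assay on HEK293 cells for antagonist activity at Voltage-dependent L-type calcium channel subunit alpha-1C (Oryctolagus cuniculus), read by FLIPR; on this read-out lower numbers stand for stronger inhibition and higher numbers for weaker inhibition. Compound 2 gives the lower of the two numbers, and compound 1 stands a clear gap away from it. Compound 3, `COC(=O)C1=C(C)NC(C)=C(C(=O)OCCc2ccc(Cl)cc2)C1c1cccc([N+](=O)[O-])c1`, has not been measured yet. It differs from compound 2 in one place: 4-chlorophenyl in place of ethynyl on a saturated chain carbon, two bonds along the chain from an oxygen next to a carbonyl group. Among the measured compounds shown here, with no measured pair covering such a change, the step of a 1.2-fold lower number from compound 2 to compound 3 (0.09 log units; within the scatter) in this assay is expected to be small, no more than the scatter, in either direction. Compound 3 is estimated at 25 nM, within a range from 8 nM to 80 nM.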

Compound 3, half-maximal inhibitory concentration: 8 nM
The estimate for compound 3 lay 3.1-fold (0.49 log units) above the measured number; measured number inside the range.
By their numbers in this assay, from the lowest: compound 3; then compound 2; then compound 1.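

In this assay, the step of a 3.9-fold lower number from compound 2 to compound 3 (0.59 log units; beyond the scatter) shows that this position on the ester chain accepts 4-chlorophenyl in place of ethynyl, and that the exchange lowers the number beyond the scatter. An aromatic ring at the chain end is therefore compatible with inhibition here, although this rests on a single pair. Nothing shown explains the step. The compounds shown leave open whether the chlorine contributes or the ring alone suffices. They also leave open how an unsubstituted phenyl, a 4-methoxyphenyl or a longer chain would read at this position.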